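Thiazole swap on the ether-linked chain: stability outlook

A few compounds are considered here, and "the series" means these few. Any claim that something is new, unique, unknown or untested is made for them only; others in the source may bear on it.

Three compounds of the shared core have been run in an ADME assay on microsomes from liver (Rattus norvegicus) for metabolic stability, read by LC-MS, tested at 0.5 uM; a lower number here means that the compound disappears faster, a higher number that the compound lasts longer. Compound 1 `COc1ccc(CCOc2ccc(-c3c(C)nc(C)c([C@H](OC(C)(C)C)C(=O)O)c3N3CCC(C)(C)CC3)cc2)cc1` reaches only the limit of the assay, > 2 h. Compound 2 `Cc1nc(C)c([C@H](OC(C)(C)C)C(=O)O)c(N2CCC(C)(C)CC2)c1-c1ccc(CCCc2ccc(F)cc2)cc1` likewise stops at the limit, > 2 h. Going by the values given here, compound 3 `Cc1nc(CCOc2ccc(-c3c(C)nc(C)c([C@H](OC(C)(C)C)C(=O)O)c3N3CCC(C)(C)CC3)cc2)cs1` gives 1.75 h, the one actual number among the three values. The other two values are the limit of > 2 h in this assay, at which 2 of the 3 values shown sit, so compound 3 is the only point in the set that can be placed on the scale.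

Among the compounds with values here, two measured steps touch the position that changes next. The step of an at least 1.1-fold lower number from compound 1 to compound 3 (0.05 log units; that floor lies within the scatter) and the step of an at least 1.1-fold lower number from compound 2 to compound 3 (0.05 log units; that floor lies within the scatter) both replace the group on the saturated chain carbon two bonds along the chain from an oxygen on an aromatic ring, and both read as a drop whose floor lies within the scatter. The step that the two limits leave unreadable from compound 1 to compound 2 cannot be read, as both ends are limits.

Compound 4 `Cc1nc(C)c(CCOc2ccc(-c3c(C)nc(C)c([C@H](OC(C)(C)C)C(=O)O)c3N3CCC(C)(C)CC3)cc2)s1` differs from compound 3 by 2,4-dimethyl-1,3-thiazol-5-yl in place of 2-methyl-1,3-thiazol-4-yl on a saturated chain carbon, two bonds along the chain from an oxygen on an aromatic ring. The steps at this position give only floors, none beyond the scatter, so no step beyond the scatter is expected in this assay, in either direction; the expected step is a 1.1-fold lower number from compound 3 to compound 4 (0.04 log units; within the scatter). For compound 4 the estimate in this assay is 1.6 h, between 0.9 h and 2.5 h, with a fair chance that only the limit is returned.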

Compound 4, half-life: > 2 h
Compound 4 ended at the assay's limit (the forecaster's own chance of this, stated with the estimate: 30%); middle value at least 1.2-fold (0.09 log units) away from the limit.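

In this assay compound 4 gives > 2 h, which is a limit of the assay and not a number. The change to 2,4-dimethyl-1,3-thiazol-5-yl on a saturated chain carbon, two bonds along the chain from an oxygen on an aromatic ring, gives an at least 1.1-fold higher number from compound 3 to compound 4 (0.05 log units; that floor lies within the scatter), so the two thiazoles are not separated here, and a thiazole in this place can reach the limit just as the 4-methoxyphenyl of compound 1 does. The steps from compound 1 and compound 2 to compound 4 cannot be read, and compound 3 remains the only compound that can be placed on the scale: the limit of > 2 h in this assay, at which 3 of the 4 values shown sit.

How far compound 1, compound 2 and compound 4 lie past the limit stays open, so any real difference among the groups at this position cannot be sized with the compounds shown. Also open, going by these compounds, is whether a pyridyl ring or a dimethylamino group in place of the thiazole on this chain would give a half-life that can be read as a number in this assay.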